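Swapping the aminopyridine arm for a dimethylaminophenyl arm

This account rests on a few compounds, and the source may have more. Where it says the series, first, only, none or still open, it means among the compounds named here.

Compound 1 `CCOC(=O)c1cnc2ccc(-c3cccc(N)c3)cc2c1` gives only a limit in a functional assay on RD cells (Homo sapiens) for inhibition, read by luminescence and ATP content, with a stated time of 72 h (a higher number here means that more compound is tolerated, a lower number that less compound is tolerated), namely > 7400 nM.
Compound 2 `CCCCc1nc(-c2cnc3ccc(-c4ccc(N)cc4)cc3c2)no1` likewise gives a limit, > 2500 nM.
Compound 3 `Nc1ccc(-c2ccc3ncc(-c4noc(C(F)(F)F)n4)cc3c2)cn1` also gives a limit, > 2500 nM.

None of the three measured compounds yields an actual number in this assay; each stands at a limit. Compound 3 shares its position with one other compound at the limit of > 2500 nM in this assay, at which 2 of the 3 values shown sit, while one compound sits at the limit of > 7400 nM in this assay, at which 1 of the 3 values shown sits. So compound 3 is among the compounds that tolerate at least as much as the assay could test.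

Compound 4 `CN(C)c1ccc(-c2ccc3ncc(-c4noc(C(F)(F)F)n4)cc3c2)cc1` is not yet measured. It differs from compound 3 by 4-(dimethylamino)phenyl in place of 6-aminopyridin-3-yl on an aromatic carbon. Among the measured compounds shown here, no pair of measured compounds shows what such a change does in this assay, so the expectation rests on the fact that all three measured compounds, compound 1, compound 2 and compound 3, stay at a limit. The step from compound 3 to compound 4 is expected to be a step that the limit leaves unreadable from compound 3 to compound 4, that is, nothing beyond the scatter. Compound 4 is therefore estimated at 5000 nM, within a range of 2000 nM to 25000 nM, most likely again as a limit.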

Compound 4, half-maximal cytotoxic concentration: > 22200 nM
Compound 4: a limit, no number; the forecaster's own chance of this, stated with the estimate: 70%; middle value at least 4.4-fold (0.64 log units) away from the limit.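

Among the compounds shown here, compound 3 and compound 4 each give only a limit in this assay, not a number, so no step between them can be read. The compounds shown leave open where the actual half-maximal cytotoxic concentration of any of them lies, and whether 4-(dimethylamino)phenyl in place of 6-aminopyridin-3-yl shifts it at all.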